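Methanesulfonamido for acetamido: cytotoxicity notes on the series

The source may report more compounds than this note shows. Statements on the series, on what has been measured and on what is new or still open speak of the compounds shown alone.

Compound 1 `O=c1c(C2=CS(=O)(=O)c3cc(F)ccc3N2)c(O)c2cc(F)ccc2n1Cc1ccc(F)cc1` carries fluoro on an aromatic carbon of the fused ring. In an ADME assay on 2209-23 cells (Homo sapiens) for cytotoxicity, read by WST assay (on this read-out higher numbers stand for lower toxicity in this test and lower numbers for higher toxicity in this test), compound 1 gives > 50000 nM, which is a limit of the assay and not a number. Compound 2 `O=c1c(C2=CS(=O)(=O)c3cc(O)ccc3N2)c(O)c2cc(F)ccc2n1Cc1ccc(F)cc1` has hydroxy in place of that fluoro. In this assay compound 2 gives > 50000 nM, again only a limit. Compound 3 `CC(=O)Nc1ccc2c(c1)S(=O)(=O)C=C(c1c(O)c3cc(F)ccc3n(Cc3ccc(F)cc3)c1=O)N2` has acetamido at the same place. In this assay compound 3 gives > 50000 nM, also a limit. The steps a step that the two limits leave unreadable from compound 1 to compound 2, a step that the two limits leave unreadable from compound 1 to compound 3 and a step that the two limits leave unreadable from compound 2 to compound 3 therefore cannot be sized, and compound 3 stands exactly where the other two values stand, at the limit of > 50000 nM in this assay, at which 3 of the 3 values shown sit.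

Compound 4 `CS(=O)(=O)Nc1ccc2c(c1)S(=O)(=O)C=C(c1c(O)c3cc(F)ccc3n(Cc3ccc(F)cc3)c1=O)N2` differs from compound 3 by methylsulfonyl in place of acetyl on a nitrogen on an aromatic ring. For the measured compounds named here, the only measured steps that touch the acetamido, a step that the two limits leave unreadable from compound 1 to compound 3 and a step that the two limits leave unreadable from compound 2 to compound 3, give no readable size or direction, so nothing argues for a move beyond the scatter in this assay in either direction. For compound 4 the expected step that the limit leaves unreadable from compound 3 to compound 4 is thus essentially flat, with the measurement most likely again ending at the assay limit. The estimate for compound 4 in this assay is 60000 nM, expected to lie between 20000 nM and 150000 nM.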

Compound 4, half-maximal cytotoxic concentration: > 50000 nM
Compound 4: a limit, no number; the forecaster's own chance of this, stated with the estimate: 85%; the middle value lies beyond the limit too.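

In this assay compound 4 gives > 50000 nM, a limit of the assay and not a number. No step among compound 1, compound 2, compound 3 and compound 4 can be read, and all four stand at the same place: the limit of > 50000 nM in this assay, at which 4 of the 4 values shown sit.

The compounds shown leave open how far apart these four lie, and at what concentration any of them would become cytotoxic.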